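Fluoro to Bromo: One Cytotoxicity Step Yet Unmeasured

The source may hold more compounds than are shown below. What is called first, only, known or untested is meant among the compounds shown, and "the series" means these compounds.

Measured so far in a functional assay on HepG2 cells (Homo sapiens) for cytotoxicity, with a stated time of 24 h; a higher number here means a weaker inhibitor, a lower number a stronger inhibitor:
compound 1 (`O=C(N/N=C/c1cc(I)c(O)c(I)c1)c1ccc(O)cc1`): 110000 nM
compound 2 (`O=C(N/N=C/c1cc(I)c(O)c(I)c1)c1ccc(F)cc1`): 117000 nM

Compound 2 stands at the highest of the two numbers; its nearest neighbour is compound 1, and the two lie within the scatter of each other. Going by the values given here, the only measured step, a 1.1-fold higher number from compound 1 to compound 2 (0.03 log units; within the scatter), exchanges hydroxy for fluoro and does not carry the pair apart.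

Compound 3 (`O=C(N/N=C/c1cc(I)c(O)c(I)c1)c1ccc(Br)cc1`) differs from compound 2 by bromo in place of fluoro on an aromatic carbon. Among the compounds with values here, no measured step exchanges one halogen for another, so the hydroxy-to-fluoro step is the only guide, and it was flat. The step from compound 2 to compound 3 in this assay is therefore expected to stay within the scatter, a 1.0-fold higher number from compound 2 to compound 3 (0.01 log units; within the scatter), with no direction favoured.

On that basis compound 3 is estimated at 120000 nM in this assay, with a range from 55000 nM to 260000 nM.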

Compound 3, half-maximal inhibitory concentration: > 50000 nM
Compound 3 was reported as a limit (the forecaster's own chance of this, stated with the estimate: 15%); the middle value lies beyond the limit too.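

In this assay compound 3 is reported only as a limit, > 50000 nM, so the steps to it from compound 1 and compound 2 cannot be read. The compounds shown leave open whether bromo, in place of fluoro or hydroxy, shifts the number at all, and in which direction.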